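The source may hold more compounds than are shown below. What is called first, only, known or untested is meant among the compounds shown, and "the series" means these compounds.

Working notes on the series. Within the data shown here, compound 2 `CCC(C(=O)N1CCN(c2ccc(Cl)cc2)CC1)N1C(=O)CCC1=O` gives 25% in a functional assay on the whole organism (strain Swiss) with Mus musculus as the target, in the maximal electroshock model, with a stated time of 1 h, at a dose of 300 mg/kg by the intraperitoneal route (a lower number here means a weaker effect, a higher number a stronger effect of the compound at the dose given), and stands highest of the three numbers so far, with both other compounds lower beyond the scatter. Compound 1 `CCC(C(=O)N1CCN(c2ccc(C(F)(F)F)cc2)CC1)N1C(=O)CCC1=O` gives 0%; the step of a number 25 percentage points higher from compound 1 to compound 2 (beyond the scatter) accompanies chloro in place of trifluoromethyl on an aromatic carbon. Compound 3 `CC(C(=O)N1CCN(c2ccc(Cl)cc2)CC1)N1C(=O)CCC1=O` gives 0%; the step of a number 25 percentage points lower from compound 2 to compound 3 (beyond the scatter) accompanies hydrogen in place of methyl on a saturated chain carbon. Compound 4 `CCC(C(=O)N1CCN(c2ccccc2Cl)CC1)N1C(=O)CCC1=O` is not yet measured. It differs from compound 2 by 2-chlorophenyl in place of 4-chlorophenyl on an amine nitrogen in a ring. Neither measured step bears directly on this change: one swaps the group on the aromatic carbon for a different group, the other alters the saturated chain, and both were modest in size. Among the measured compounds shown here, no measured pair shows a chlorophenyl moved from one ring carbon to another, so the direction is open. Given that compound 2 holds the top number and every measured change away from it lowered the read-out, a modest step downward, or none beyond the scatter, is expected: a number 10 percentage points lower from compound 2 to compound 4 (within the scatter). Compound 4 is estimated at 15%, within 0% to 40%.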

Compound 4, a percentage reported as activity, at one dose (the size of the read-out at that dose, not a potency): 50%
The estimate for compound 4 lay 35 percentage points below the measured number; the measured number lies above the stated range.
By their numbers in this assay, from the lowest: compounds 1 and 3 (each within the scatter of the next); then compound 2; then compound 4.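

In this assay, 2-chlorophenyl in place of 4-chlorophenyl on the amine nitrogen in a ring gives a number 25 percentage points higher from compound 2 to compound 4 (beyond the scatter), a step that changes how the atoms are joined while the atoms themselves stay the same. The earlier steps shown here exchanged one group for another or altered the saturated chain, whereas this pair shows that the read-out also responds to where the chlorine sits on the phenyl ring. No measurement at hand accounts for this step.

From the compounds shown here alone, whether the step carries over to bromine or a methoxy group in place of the chlorine on the 2-chlorophenyl remains open, as does the effect of hydrogen in place of methyl on the saturated chain of compound 4. Going by these compounds, the read-out comes from a single dose, so the relative potency of compound 2 and compound 4 is also open.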